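The source may hold more compounds than are shown below. What is called first, only, known or untested is meant among the compounds shown, and "the series" means these compounds.

Measured compounds in a functional assay on T47D cells (Homo sapiens) for activation; on this read-out higher numbers stand for an effect only at larger amounts of compound and lower numbers for an effect already at smaller amounts: compound 1 `CCOc1ccc2c(c1)OC(N)=C(C#N)C2c1cc(Br)c(OC)c(OC)c1` gives 64000000 nM; compound 2 `COc1ccc2c(c1)OC(N)=C(C#N)C2c1cc(Br)c(OC)c(OC)c1` gives 17000000 nM; compound 3 `COc1cc(C2C(C#N)=C(N)Oc3cc(N)ccc32)cc(Br)c1OC` gives 33000000 nM.

In this assay compound 3 stands within the scatter of both compound 1 and compound 2, so the three numbers give no firm order around it. Compound 4 `COc1cc(C2C(C#N)=C(N)Oc3cc(Cl)ccc32)cc(Br)c1OC` differs from compound 3 by chloro in place of amino on an aromatic carbon. Within the data shown here, the steps that touch this ring carbon are a 1.9-fold lower number from compound 1 to compound 3 (0.29 log units; within the scatter) and a 1.9-fold higher number from compound 2 to compound 3 (0.29 log units; within the scatter), both within the scatter; no measured step introduces chloro at this position. On this basis the account expects for compound 4 no change at the digits printed from compound 3 to compound 4 (within the scatter), that is, no change beyond the scatter. Compound 4 is therefore estimated at 33000000 nM, within a range of 8000000 nM to 130000000 nM.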

Compound 4, half-maximal effective concentration: 160000000 nM
For compound 4 the middle estimate is 4.8-fold (0.69 log units) below the measured one; measured number outside the range, above it.
By their numbers in this assay, from the lowest: compounds 2, 3 and 1 (each within the scatter of the next, the first and the last beyond it); then compound 4.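

Chloro is the first group at this ring carbon whose number lies beyond the scatter of every other group shown, whether it replaces amino (a 4.8-fold higher number from compound 3 to compound 4 (0.69 log units; beyond the scatter)), methoxy (a 9.4-fold higher number from compound 2 to compound 4 (0.97 log units; beyond the scatter)) or ethoxy (a 2.5-fold higher number from compound 1 to compound 4 (0.40 log units; beyond the scatter)). In this assay this position therefore responds to the group placed on it, and compound 4 carries the highest number of the four. Nothing available accounts for this shift. On these data alone, whether fluoro, bromo, hydroxyl or a carboxylic acid at this carbon would behave like chloro stays open. So does whether the chloro step would hold with other groups on the second aromatic ring.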